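The compounds below may be only part of what the source reports. "The series", "measured", "known", "first", "only" and "open" are said of these compounds alone.

Measured compounds:
Compound 1 `COc1ccccc1C1CC(C)=NN1C(=O)C[N+]1(C)CCCC1` — 11200 nM
Compound 2 `CCC(=O)N1N=C(c2cc3ccccc3oc2=O)CC1c1ccccc1` — 4370 nM

In a functional assay on PC-3 cells (Homo sapiens) for cytotoxicity, read by MTT assay, with a stated time of 48 h (on this read-out lower numbers stand for stronger inhibition and higher numbers for weaker inhibition), compound 2 gives 4370 nM, the lower of the two numbers, while compound 1 gives 11200 nM, a gap that goes beyond the usual scatter. Compound 3 `O=C(CN1CCCC1)N1N=C(c2cc3ccccc3oc2=O)CC1c1ccccc1` is not yet measured. It differs from compound 2 by pyrrolidin-1-yl in place of methyl on a saturated chain carbon bound to a carbonyl carbon. Going by the values given here, no measured pair shows this kind of change, so the expected step from compound 2 to compound 3 is set at a 1.1-fold higher number from compound 2 to compound 3 (0.06 log units; within the scatter), that is, within the scatter and in no firm direction. Compound 3 is thus estimated at 5000 nM, with a range from 1500 nM to 16000 nM.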

Compound 3, half-maximal inhibitory concentration: 50200 nM
Compound 3: middle estimate off by 10-fold (1.00 log units), on the low side, outside the stated range (above it).
By their numbers in this assay, from the lowest: compound 2; then compound 1; then compound 3.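

In this assay pyrrolidin-1-yl in place of methyl, on a saturated chain carbon bound to a carbonyl carbon, brings an 11-fold higher number from compound 2 to compound 3 (1.06 log units; beyond the scatter) and thus much weaker inhibition. Going by these compounds alone, this is the first sign that this place on the shared core matters: one change here moves the number well beyond the usual scatter. Nothing available explains this drop.

Still open, on these data alone, is whether a dimethylamino group or a cyclopentyl ring at this place would behave the same way, which would help separate the effect of the ring from that of its nitrogen.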